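The source may hold more compounds than are shown below. What is called first, only, known or untested is meant among the compounds shown, and "the series" means these compounds.

Compound 1: `NC(=O)c1sc2ccccc2c1O` — > 100000 nM
Compound 2: `NNC(=O)c1sc2ncccc2c1N` — > 100000 nM
Compound 3: `NC(=O)c1sc2nc(Cc3ccccc3)cc(C(F)(F)F)c2c1N` — 30000 nM

All three were tested in an assay on isolated protein for inhibition of LIM domain kinase 1 (Homo sapiens), read by Kinase-Glo, with a stated time of 60 min; a higher number here means a weaker inhibitor, a lower number a stronger inhibitor. For compound 1 the result > 100000 nM is a limit of the assay, not a measured number. Compound 2 likewise reaches only a limit. Compound 3 alone gives a number, 30000 nM. Compound 1 therefore stands at the limit of > 100000 nM in this assay, at which 2 of the 3 values shown sit.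

The next compound, compound 4 with the structure `NC(=O)c1sc2ccccc2c1N`, differs from compound 1 by amino in place of hydroxy on an aromatic carbon. Among the measured compounds shown here, no measured pair shows this change, so its effect in this assay cannot be read from the data. The expected step is a number no higher from compound 1 to compound 4 (the limit leaves the size open), within the usual scatter. Compound 4 is estimated at 100000 nM, with a range from 30000 nM to 300000 nM.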

Compound 4, half-maximal inhibitory concentration: 33000 nM
Beside the measured number, compound 4's estimate is 3.0-fold (0.48 log units) above it; measured number inside the range.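

Putting amino in place of hydroxy on this aromatic carbon gives, in this assay, an at least 3.0-fold lower number from compound 1 to compound 4 (0.48 log units; beyond the scatter). Among the compounds shown here, this is the first one-place comparison, and it shows that the group at this position can change the result on the shared core. Compound 1 reaches only a limit, so the step gives a minimum and not a full size: the limit of > 100000 nM in this assay, at which 2 of the 4 values shown sit.

The compounds shown leave open how a methylamino or methoxy group would compare with amino at this position. They also leave open whether a carboxylic acid could replace the carbamoyl group on the core of compound 4.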